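This account rests on a few compounds, and the source may have more. Where it says the series, first, only, none or still open, it means among the compounds named here.

Of the compounds shown here, three with a shared core have been measured in an assay on HeLa cells for displacement of a labelled ligand from 5-hydroxytryptamine receptor 6 (Homo sapiens); on this read-out higher numbers stand for weaker inhibition and lower numbers for stronger inhibition. Compound 1 `O=S(=O)(c1cccc(Br)c1)c1cn(C2CCNC2)c2ncccc12` gives 1.3 nM. Compound 2 `O=S(=O)(c1cccc(C(F)(F)F)c1)c1cn(C2CCNC2)c2ncccc12` gives 1.3 nM, and the step of no change at the digits printed from compound 1 to compound 2 (within the scatter) shows that trifluoromethyl in place of bromo on an aromatic carbon left the number where it was. Compound 3 `CN1CCC(n2cc(S(=O)(=O)c3ccccc3)c3cccnc32)C1` gives 2.5 nM, the highest of the three numbers, though its gaps to compound 1 and to compound 2 both lie within the scatter. Compound 4 `CN1CCC(n2cc(S(=O)(=O)c3ccccc3Cl)c3cccnc32)C1` differs from compound 3 by chloro in place of hydrogen on an aromatic carbon, a chloro on an aromatic carbon ortho to a large group. Among the measured compounds shown here, the only measured step touching that ring showed no change, so compound 4 is expected to move little, a 1.1-fold lower number from compound 3 to compound 4 (0.06 log units; within the scatter). Compound 4 is therefore estimated at 2.2 nM, between 0.7 nM and 7 nM.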

Compound 4, inhibition constant: 2.2 nM
Estimate against measurement, compound 4: no gap at the digits printed; the range from low to high includes it.
By their numbers in this assay, from the lowest: compounds 1, 2, 4 and 3 (each within the scatter of the next).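

In this assay, chloro in place of hydrogen, ortho to a large group, gives a 1.1-fold lower number from compound 3 to compound 4 (0.06 log units; within the scatter), so turning phenyl into 2-chlorophenyl stays within the scatter. The earlier step only exchanged one group on the ring for another, whereas this one shows a group added where there was only hydrogen. Nothing available explains this result. As far as these compounds go, whether an amine or a carboxylic acid at this same place would also stay within the scatter remains open. So does the effect of a longer chain there, such as a butyl group.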